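This account rests on a few compounds, and the source may have more. Where it says the series, first, only, none or still open, it means among the compounds named here.

Working notes on the series, continued.

Compound 1 `COCC(COC)Nc1nc(C)nc2c(-c3ccc(OC)cc3C)c(C)nn12` and compound 2 `COc1ccc(-c2c(C)nn3c(NC4CCC4)nc(C)nc23)c(C)c1` share one core and differ only in the group on the ring nitrogen-bound amine. In an assay on cell membranes for displacement of a labelled ligand from corticotropin-releasing factor receptor 1 (Rattus norvegicus) (on this read-out higher numbers stand for weaker inhibition and lower numbers for stronger inhibition), compound 1 gives 9.7 nM, and in this assay compound 2 gives 24.6 nM. Across these two numbers compound 2 holds the higher one; the only step, a 2.5-fold higher number from compound 1 to compound 2 (0.40 log units; beyond the scatter), is modest and lies beyond the scatter.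

Compound 3 `COc1ccc(-c2c(C)nn3c(N4CCCC4)nc(C)nc23)c(C)c1` is not yet measured. It differs from compound 2 as follows: pyrrolidin-1-yl in place of cyclobutylamino on an aromatic carbon. Among the compounds with values here, this change keeps the count of heavy atoms and removes the hydrogen-bond donor; the only measured step touches the same position but swaps one amine substituent for another and keeps the donor, so it gives a loose reference at best. Within the data shown here, since the single step at this position, a 2.5-fold higher number from compound 1 to compound 2 (0.40 log units; beyond the scatter), was modest, a step of comparable or somewhat larger size is expected here, with the direction leaning toward weaker inhibition but not firmly settled. On that basis compound 3 is expected to show a 1.6-fold higher number from compound 2 to compound 3 (0.21 log units; within the scatter), with an estimate of 40 nM in this assay, ranging from 10 nM to 160 nM.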

Compound 3, half-maximal inhibitory concentration: 80.7 nM
Estimate against measurement, compound 3: 2.0-fold (0.30 log units) below, and the stated range covers the measured number.
By their numbers in this assay, from the lowest: compound 1; then compound 2; then compound 3.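

In this assay, pyrrolidin-1-yl in place of cyclobutylamino on the aromatic carbon between two ring nitrogen atoms gives a 3.3-fold higher number from compound 2 to compound 3 (0.52 log units; beyond the scatter), so a swap that leaves the count of heavy atoms unchanged still produces a step beyond the scatter at this position. Both earlier amine substituents carry a hydrogen-bond donor and pyrrolidin-1-yl carries none; set against the (2-methoxy-1-(methoxymethyl)ethyl)amino group, the same replacement gives an 8.3-fold higher number from compound 1 to compound 3 (0.92 log units; beyond the scatter), and compound 3 stands highest of the three on this read-out. The swap alters the donor count and the ring together, so these numbers do not separate the two changes, and nothing at hand speaks to what lies behind the step.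

Open, going by these compounds, is whether cyclobutyl(methyl)amino, which has no donor but keeps the four-membered carbon ring, would sit nearer compound 2 or compound 3. Equally open, on these data alone, is where cyclopentylamino, which keeps the donor and has a five-membered ring of carbon only, would fall.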